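The source may hold more compounds than are shown below. What is called first, only, known or untested is meant among the compounds shown, and "the series" means these compounds.

Measured compounds in a functional assay on CCRF-CEM cells (Homo sapiens); a lower number here means that less compound is tolerated, a higher number that more compound is tolerated:
- compound 1, `Cc1cn([C@@H]2O[C@H](CO[Si](C)(C)C(C)(C)C)[C@@]3(OS(=O)(=O)C=C3NC(=O)c3ccccc3)[C@H]2O[Si](C)(C)C(C)(C)C)c(=O)n(C)c1=O`: 4910 nM
- compound 2, `COC(=O)CC(=O)NC1=CS(=O)(=O)O[C@@]12[C@@H](CO[Si](C)(C)C(C)(C)C)O[C@@H](n1cc(C)c(=O)n(C)c1=O)[C@@H]2O[Si](C)(C)C(C)(C)C`: 29700 nM
- compound 3, `C=C(C)C(=O)NC(=O)NC1=CS(=O)(=O)O[C@@]12[C@@H](CO[Si](C)(C)C(C)(C)C)O[C@@H](n1cc(C)c(=O)n(C)c1=O)[C@@H]2O[Si](C)(C)C(C)(C)C`: 1200 nM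

Compound 1 stands second highest of the three numbers. Its nearest neighbour is compound 3, reached by a 4.1-fold lower number from compound 1 to compound 3 (0.61 log units; beyond the scatter); furthest is compound 2, reached by a 6.0-fold higher number from compound 1 to compound 2 (0.78 log units; beyond the scatter). Both steps alter the group on the carbonyl carbon of the amide and both lie beyond the scatter.

Compound 4, `Cc1cn([C@@H]2O[C@H](CO[Si](C)(C)C(C)(C)C)[C@@]3(OS(=O)(=O)C=C3NCC(=O)OCc3ccccc3)[C@H]2O[Si](C)(C)C(C)(C)C)c(=O)n(C)c1=O`, differs from compound 1 at the amine nitrogen: (benzyloxycarbonyl)methyl in place of benzoyl on an amine nitrogen. After the change no carbonyl remains on the amine nitrogen; the entering group carries its carbonyl as an ester. Going by the values given here, of the measured steps, only the step from compound 1 to compound 2 bears on this, as it likewise exchanges the phenyl for an ester-bearing group and gave a modest higher number. The step from compound 2 to compound 3, a 25-fold lower number from compound 2 to compound 3 (1.39 log units; beyond the scatter), concerns the acyl urea and does not transfer here. Among the compounds with values here, the loss of the amide itself has no measured precedent, so the expectation is uncertain.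

A modest higher number is therefore expected, roughly a 2.4-fold higher number from compound 1 to compound 4 (0.39 log units; beyond the scatter). Compound 4 is estimated at 12000 nM, within 4000 nM to 40000 nM.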

Compound 4, half-maximal cytotoxic concentration: 250000 nM
Estimate against measurement, compound 4: 21-fold (1.32 log units) below, outside the stated range (above it).
By their numbers in this assay, from the lowest: compound 3; then compound 1; then compound 2; then compound 4.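

In this assay, a 51-fold higher number from compound 1 to compound 4 (1.71 log units; beyond the scatter) shows that this amine nitrogen is far from indifferent to what it carries: a change that leaves no carbonyl on the nitrogen moves the number well past the spread seen among the three earlier compounds, all of which keep a carbonyl there. The other two steps agree, an 8.4-fold higher number from compound 2 to compound 4 (0.93 log units; beyond the scatter) and a 210-fold higher number from compound 3 to compound 4 (2.32 log units; beyond the scatter), so compound 4 holds the highest number of the four, and an ester in the entering group does not by itself set the size of the rise, since compound 2 also carries an ester and stays lower. No measurement on hand speaks to why the number rises at this position.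

Still open, on these data alone, is whether the rise follows from the loss of the carbonyl on the nitrogen or from the (benzyloxycarbonyl)methyl chain itself. A free amine, a simple benzyl on the nitrogen, or a carboxylic acid in place of the benzyl ester would help separate these readings.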